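This account rests on a few compounds, and the source may have more. Where it says the series, first, only, none or still open, it means among the compounds named here.

Measured compounds in this series:
compound 1 `COC/C1=C/C[C@](C)(CCC=C(C)C)/C=C/[C@@H](OC(=O)C=C(C)C)[C@](C)(OC)/C=C/C1=O`, 14600 nM
compound 2 `COC/C1=C/C[C@](C)(CCC=C(C)C)/C=C/[C@@H](OC(=O)C=C(C)C)[C@](C)(O)/C=C/C1=O`, 3850 nM
compound 3 `CO[C@]1(C)/C=C/C(=O)/C(CO)=C\C[C@](C)(CCC=C(C)C)/C=C/[C@H]1OC(=O)C=C(C)C`, 15200 nM

In a functional assay on SW480 cells (Homo sapiens) for antiproliferative activity, read by MTT assay, with a stated time of 48 h (on this read-out higher numbers stand for weaker inhibition and lower numbers for stronger inhibition), compound 2 gives the lowest number of the three. Against compound 1 the gap is a 3.8-fold lower number from compound 1 to compound 2 (0.58 log units; beyond the scatter), whereas a 1.0-fold higher number from compound 1 to compound 3 (0.02 log units; within the scatter) leaves compound 1 and compound 3 indistinguishable. Both measured steps swap hydrogen for methyl on an oxygen on a saturated carbon, at different positions of the shared core.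

Compound 4 `CC(C)=CCC[C@]1(C)/C=C/[C@@H](OC(=O)C=C(C)C)[C@](C)(O)/C=C/C(=O)/C(C(=O)N2CCCC2)=C\C1` is not yet measured. Its change from compound 2 is (pyrrolidin-1-yl)carbonyl in place of methoxymethyl on a double-bonded ring carbon. For the measured compounds named here, neither measured step touches the methoxymethyl group or the double-bonded ring carbon that carries it, so no measured step bears on this change. The hydroxy group that distinguishes compound 2 from compound 1 is kept in compound 4.

Going by the values given here, with no precedent for this substitution, the expectation can only be anchored on the value of compound 2 in this assay, with a wide range in either direction. On that basis compound 4 is expected to give 5000 nM in this assay, with a range of 1200 nM to 25000 nM. The step this estimate means is a 1.3-fold higher number from compound 2 to compound 4 (0.11 log units; within the scatter), which is expected to fall within the usual scatter.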

Compound 4, half-maximal inhibitory concentration: 15100 nM
Compound 4: the middle estimate sits 3.0-fold (0.48 log units) below what was measured, and the stated range covers the measured number.
By their numbers in this assay, from the lowest: compound 2; then compounds 1, 4 and 3 (each within the scatter of the next).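

In this assay, the double-bonded ring carbon that carries the methoxymethyl group does not tolerate every replacement: (pyrrolidin-1-yl)carbonyl, with 7 heavy atoms in place of 3, gives a 3.9-fold higher number from compound 2 to compound 4 (0.59 log units; beyond the scatter), a modest step. The hydroxy group that separates compound 2 from compound 1 is retained in compound 4, so keeping it does not by itself preserve the number of compound 2 once this ring carbon is changed. No supporting measurement bears on why this step occurs.

This single replacement changes several features at once, so the compounds shown do not tell whether the higher number goes with the carbonyl attached directly to the ring carbon or with the pyrrolidine ring. A dimethylaminocarbonyl group, a carboxylic acid or a hydroxymethyl group at this carbon, each with the hydroxy group of compound 2 retained, would help to separate these features and show whether any replacement here can match or improve on compound 2.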